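The source may report more compounds than this note shows. Statements on the series, on what has been measured and on what is new or still open speak of the compounds shown alone.

Among the compounds with values here, in a functional assay on U-937 cells (Homo sapiens) for cytotoxicity, read by CCK-8 assay, with a stated time of 72 h (a lower number here means a stronger inhibitor, a higher number a weaker inhibitor), compound 3 `C=CCn1c(=O)/c(=C\c2ccccc2OC)[nH]c(=O)/c1=C\c1ccccc1OC` is the only member of this small set with a numerical result, giving 5100 nM. Compound 1 `COc1ccccc1/C=c1/[nH]c(=O)/c(=C\c2ccccc2OC)[nH]c1=O` was reported in this assay as "not active" (no number reported). Compound 2 `C=CCn1c(=O)/c(=C\c2ccc(Cl)c(Cl)c2)[nH]c(=O)/c1=C\c1ccccc1` was likewise reported in this assay as "not active" (no number reported). Compound 4 `C=CCn1c(=O)/c(=C\c2ccc(Cl)c(Cl)c2)[nH]c(=O)/c1=C\c1ccccc1OC` differs from compound 3 by 3,4-dichlorophenyl in place of 2-methoxyphenyl on a double-bonded chain carbon bound to an aromatic carbon. Within the data shown here, no measured pair here isolates this change, so its size is uncertain; compound 2, which also carries the 3,4-dichlorophenyl group, showed "not active" (no number reported), which points toward weaker inhibition. Compound 4 is therefore expected to show a loss of potency, estimated at a 2.4-fold higher number from compound 3 to compound 4 (0.37 log units; beyond the scatter). For compound 4 an inhibitory concentration of about 12000 nM is expected, in the range 4000 nM to 40000 nM, with a real chance that only inactivity is reported.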

Compound 4, half-maximal inhibitory concentration: "not active" (no number reported)
Compound 4: no number reported; no gap can be computed for the estimate.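

Within the data shown here, compound 4 carries no number, so no step from compound 3 to compound 4 can be read. The compounds shown leave open how large the change from 2-methoxyphenyl to 3,4-dichlorophenyl is. Nothing given here bears on its cause.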